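A few compounds are considered here, and "the series" means these few. Any claim that something is new, unique, unknown or untested is made for them only; others in the source may bear on it.

Compound 1 `CCN1CCN(c2cc(C)c3cc(NC(=O)c4cccc(Cl)c4)ccc3n2)CC1` is tested in a functional assay on MCF7 cells (Homo sapiens) for antiproliferative activity, read by MTT assay, with a stated time of 72 h (on this read-out higher numbers stand for weaker inhibition and lower numbers for stronger inhibition), where compound 1 gives 3820 nM. Compound 2 `Cc1cc(NCCN(C)C)nc2ccc(NC(=O)c3ccc(Cl)c(Cl)c3)cc12` gives 2550 nM in this assay, a number within the scatter of compound 1. Compound 3 `CCN(CC)CCNc1cc(C)c2cc(NC(=O)c3ccc(Cl)c(Cl)c3)ccc2n1` gives 1420 nM in this assay, a number that lies beyond the scatter from compound 1. The one measured step that links two of these compounds, a 1.8-fold lower number from compound 2 to compound 3 (0.25 log units; within the scatter), concerns the amine on the saturated chain and not the halogen on the benzamide ring.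

Compound 4 `CCN1CCN(c2cc(C)c3cc(NC(=O)c4cccc(F)c4)ccc3n2)CC1` differs from compound 1 at the benzamide ring only: fluoro in place of chloro on an aromatic carbon. For the measured compounds named here, no measured step in this set touches that halogen, so nothing among the three numbers bears directly on the exchange of chloro for fluoro, and the only recorded step, which sits elsewhere in the molecule, stays within the scatter. With no evidence pointing one way or the other, the expectation is a number close to that of compound 1, with no step beyond the scatter in either direction. For compound 4 the estimated step is a 1.2-fold higher number from compound 1 to compound 4 (0.07 log units; within the scatter). Compound 4 is therefore expected to give about 4500 nM, with a likely range from 1500 nM to 13000 nM.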

Compound 4, half-maximal inhibitory concentration: 8920 nM
For compound 4 the middle estimate is 2.0-fold (0.30 log units) below the measured one, within the range that was stated.
By their numbers in this assay, from the lowest: compounds 3, 2 and 1 (each within the scatter of the next, the first and the last beyond it); then compound 4.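

In this assay, for the compounds shown here, the exchange of chloro for fluoro, with the rest of compound 1 unchanged, gives a 2.3-fold higher number from compound 1 to compound 4 (0.37 log units; beyond the scatter) and is the first step in this set that touches the halogen on the benzamide ring. It is also the only listed step that lies beyond the scatter, so this place on the ring, meta to a large group, is not indifferent to which halogen it carries, even though the exchange replaces one heavy atom with one heavy atom and alters no hydrogen-bond donor, hydrogen-bond acceptor or net charge. Nothing available bears on the origin of this step, which therefore stands as an observation only.

The compounds shown leave open how bromo, methoxy, nitrile or trifluoromethyl in the same place would compare with chloro and fluoro, so a single exchange does not yet give a trend across substituents. They also leave open whether fluoro in place of chloro gives a step of similar size in a compound with a dimethylamino or diethylamino chain.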